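The source may hold more compounds than are shown below. What is called first, only, known or untested is meant among the compounds shown, and "the series" means these compounds.

Measured so far in an ADME assay on NIH3T3 cells (Mus musculus) for cytotoxicity, with a stated time of 72 h; on this read-out higher numbers stand for weaker inhibition and lower numbers for stronger inhibition:

Compound 1, `OC[C@H]1O[C@@H](n2cnc3c(NCc4ccc(F)cc4)ncnc32)[C@H](O)[C@@H]1O`: 44300 nM
Compound 2, `OC[C@H]1O[C@@H](n2cnc3c(NCc4cccc(Br)c4)ncnc32)[C@H](O)[C@@H]1O`: > 166000 nM
Compound 3, `COc1cccc(CNc2ncnc3c2ncn3[C@@H]2O[C@H](CO)[C@@H](O)[C@H]2O)c1`: > 166000 nM

The three compounds share one core and differ only in the group on a saturated chain carbon bound to a nitrogen on an aromatic ring. Compound 1, with 4-fluorophenyl there, gives a number in this assay. For compound 2 the read-out is only a limit of the assay, (the limit of > 166000 nM in this assay, at which 2 of the 3 values shown sit), not a number. Compound 3 sits at the same limit.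

Compound 4, `OC[C@H]1O[C@@H](n2cnc3c(NCc4ccc(F)cc4F)ncnc32)[C@H](O)[C@@H]1O`, has not yet been measured. Its change from compound 2 is 2,4-difluorophenyl in place of 3-bromophenyl on a saturated chain carbon bound to a nitrogen on an aromatic ring. Among the measured compounds shown here, the one measured step that bears on it is an at least 3.7-fold higher number from compound 1 to compound 2 (0.57 log units; beyond the scatter), which goes from the compound with a single fluorine to the compound at the limit. Compound 4 carries two fluorines and no bromine, so a downward step from the limit is expected, though the limit on compound 2 keeps its size uncertain. In this assay compound 4 is expected to give 80000 nM, between 30000 nM and 166000 nM, a step of an at least 2.0-fold lower number from compound 2 to compound 4 (0.31 log units; beyond the scatter).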

Compound 4, half-maximal inhibitory concentration: > 166000 nM
Compound 4 ended at the assay's limit (the forecaster's own chance of this, stated with the estimate: 40%); middle value at least 2.0-fold (0.31 log units) away from the limit.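

In this assay, among the compounds shown here, the one readable new step is an at least 3.7-fold higher number from compound 1 to compound 4 (0.57 log units; beyond the scatter). It comes from fluoro in place of hydrogen on an aromatic carbon, so the read-out at this position responds to a single added fluorine, and not only to the exchange of 4-fluorophenyl for a differently substituted group seen in compound 2 and compound 3. Compound 4 gives only a limit, not a number, and the steps linking it to compound 2 and compound 3 cannot be read, so compound 1 remains the only compound with a number: the limit of > 166000 nM in this assay, at which 3 of the 4 values shown sit.

Going by these compounds, how compound 2, compound 3 and compound 4 rank among themselves stays open, since all three sit at the limit. Also open, on these data alone, is whether a 4-chlorophenyl group, a 4-aminophenyl group or a longer chain in this place would give a number rather than a limit.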